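Benzyl in place of ethyl on an inactive amino acid

A few compounds are considered here, and "the series" means these few. Any claim that something is new, unique, unknown or untested is made for them only; others in the source may bear on it.

Compound 1 `CNC(C(=O)O)c1cc(O)no1`: > 1000000 nM
Compound 2 `CCNC(C(=O)O)c1cc(O)no1`: > 1000000 nM

In a functional assay (Rattus norvegicus) for agonist activity at metabotropic glutamate receptor 2 (Homo sapiens) (on this read-out lower numbers stand for an effect already at smaller amounts and higher numbers for an effect only at larger amounts of compound), compound 1 gives only a limit of the assay, > 1000000 nM. Compound 2 likewise gives only a limit in this assay, > 1000000 nM. The step that the two limits leave unreadable from compound 1 to compound 2 cannot be read, since (the limit of > 1000000 nM in this assay, at which 2 of the 2 values shown sit). Compound 3 `O=C(O)C(NCc1ccccc1)c1cc(O)no1` carries phenyl in place of methyl on a saturated chain carbon bound to an amine nitrogen. The one measured step on the same carbon left compound 2 at the limit, so nothing among these data points to a gain in potency. Compound 3 is therefore expected to remain at or near the limit, with an estimated value of 1000000 nM (range 300000 nM to 3000000 nM), an expected step of a number no higher from compound 2 to compound 3 (the limit leaves the size open).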

Compound 3, half-maximal effective concentration: > 1000000 nM
Compound 3: only a limit was reported (the forecaster's own chance of this, stated with the estimate: 85%); the middle value sits exactly at the limit.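

Among the compounds shown here, no step among compound 1, compound 2 and compound 3 can be read in this assay because all three stand at a limit: the limit of > 1000000 nM in this assay, at which 3 of the 3 values shown sit. The compounds shown leave open how their potencies compare and which change to the shared core would give a measurable value.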